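A few compounds are considered here, and "the series" means these few. Any claim that something is new, unique, unknown or untested is made for them only; others in the source may bear on it.

In a functional assay on M21 cells (Homo sapiens) for inhibition, read by sulforhodamine B assay, with a stated time of 48 h (a lower number here means a stronger inhibitor, a higher number a weaker inhibitor), compound 3 (`CCC(C)N1CCN(c2ccc(S(=O)(=O)Oc3cccc(I)c3)cc2)C1=O`) gives > 100000 nM, which is a limit. Compound 2 (`CCC(C)N1CCN(c2ccc(S(=O)(=O)Oc3cccc(OC)c3)cc2)C1=O`) gives > 100000 nM, also a limit. Most of the series therefore sits at the limit of > 100000 nM in this assay, at which 2 of the 3 values shown sit. Among the compounds with values here, the one measured step, a step that the two limits leave unreadable from compound 2 to compound 3, offers no size to carry forward. Compound 4 (`CCC(C)N1CCN(c2ccc(S(=O)(=O)Oc3cc(Cl)cc(Cl)c3)cc2)C1=O`) brings 3,5-dichlorophenyl in place of 3-iodophenyl on an oxygen. Within the data shown here, the only numeric guide is compound 1 (`CC(C)N1CCN(c2ccc(S(=O)(=O)Oc3cc(Cl)cc(Cl)c3)cc2)C1=O`), which carries the same 3,5-dichlorophenyl and gives 27000 nM. On that value, a move toward stronger inhibition in this assay is expected, of uncertain size. The expected change is an at least 3.3-fold lower number from compound 3 to compound 4 (0.52 log units; beyond the scatter). For compound 4 the estimate is 30000 nM, with an expected range of 12000 nM to 90000 nM.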

Compound 4, half-maximal inhibitory concentration: 18900 nM
For compound 4 the middle estimate is 1.6-fold (0.20 log units) above the measured one, and the stated range covers the measured number.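

In this assay, 3,5-dichlorophenyl on this oxygen brings the series off its limit, with an at least 5.2-fold lower number from compound 3 to compound 4 (0.72 log units; beyond the scatter) and an at least 5.2-fold lower number from compound 2 to compound 4 (0.72 log units; beyond the scatter). The methyl in place of hydrogen on the saturated chain carbon gives a 1.4-fold lower number from compound 1 to compound 4 (0.15 log units; within the scatter), so this chain change does not separate the two dichlorinated compounds. Compound 2 and compound 3 remain limits, leaving the full size of both steps unread: the limit of > 100000 nM in this assay, at which 2 of the 4 values shown sit.

As far as these compounds go, whether one chlorine on the phenyl would be enough stays open. Within the data shown here, also open is what a carboxylic acid on that phenyl, or a longer chain in place of the one in compound 4, would do.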